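This account rests on a few compounds, and the source may have more. Where it says the series, first, only, none or still open, it means among the compounds named here.

Measured in a functional assay on MCF7 cells (Homo sapiens) for inhibition, read by sulforhodamine B assay, with a stated time of 48 h; on this read-out lower numbers stand for stronger inhibition and higher numbers for weaker inhibition:
- compound 1 `COc1ccc(C(O)(Cc2ccc(C)cc2)c2cccc3ccccc23)c(OC)c1OC`: > 20000 nM
- compound 2 `COc1ccc(C(OCc2ccccc2)c2cccc3ccccc23)c(OC)c1OC`: 14100 nM

The entry for compound 1 is a limit of the assay, not a number. For the measured compounds named here, compound 2, at 14100 nM, therefore holds the only actual number. Compound 3 `COc1ccc(C(c2ccc(O)cc2)c2cccc3ccccc23)c(OC)c1OC` carries 4-hydroxyphenyl in place of benzyloxy on a saturated chain carbon bound to two aromatic carbons. Going by the values given here, no measured pair tests this change, so the expectation is loose. A modest expected gain in this assay, a 2.4-fold lower number from compound 2 to compound 3 (0.37 log units; beyond the scatter), may barely clear the scatter. For compound 3 the estimated value is 6000 nM, with an expected range of 1200 nM to 20000 nM.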

Compound 3, half-maximal inhibitory concentration: 17500 nM
Estimate against measurement, compound 3: 2.9-fold (0.46 log units) below; the range from low to high includes it.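

In this assay, 4-hydroxyphenyl in place of benzyloxy on a saturated chain carbon bound to two aromatic carbons gives a 1.2-fold higher number from compound 2 to compound 3 (0.09 log units; within the scatter), so the two compounds cannot be told apart. At this position, the exchange of one aromatic group for the other, with a hydrogen-bond donor gained, brings no measurable gain in inhibition. Compound 1 remains a limit rather than a number, and the series stays close to that limit: the limit of > 20000 nM in this assay, at which 1 of the 3 values shown sits.

On these data alone, whether an amine or a carboxylic acid on this carbon would give a lower number remains open. So does the effect of a longer chain carrying the aromatic ring.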